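This account rests on a few compounds, and the source may have more. Where it says the series, first, only, none or still open, it means among the compounds named here.

Compound 1 `Cc1cc(C)cc(OCCCON2C(N)=NC(N)=NC23CCOCC3)c1` gives 88.6% in an assay on isolated protein for inhibition of Dihydrofolate reductase (Homo sapiens), read by spectrophotometry, using NADPH, with stated times of 5 s and 6 min, tested at 50 uM; on this read-out lower numbers stand for a weaker effect and higher numbers for a stronger effect at the one concentration tested. Compound 2 `NC1=NC2(CCOCC2)N(OCCCOc2ccc(Cl)c(Cl)c2)C(N)=N1` gives "not determined" (no result reported) in this assay, so its place against compound 1 cannot be stated. Compound 3 `NC1=NC2(CCOCC2)N(OCCCOc2cccc(Br)c2)C(N)=N1` differs from compound 2 by 3-bromophenyl in place of 3,4-dichlorophenyl on an oxygen on a saturated carbon. Among the compounds with values here, since compound 2 has no result, no measured step is available, and the change itself gives no ground for a step beyond the scatter in either direction in this assay; the only measured anchor is compound 1. Compound 3 is therefore estimated at 80% in this assay, with an expected range from 55% to 95%.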

Compound 3, a percentage reported as inhibition, at one concentration (the size of the read-out at that concentration, not a potency): 85.8%
The estimate for compound 3 lay 5.8 percentage points below the measured number; measured number inside the range.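

In this assay, 3-bromophenyl in place of 3,5-dimethylphenyl on an oxygen on a saturated carbon gives a number 2.8 percentage points lower from compound 1 to compound 3 (within the scatter), so this position now has two measured groups that read alike at the one concentration tested. Steps involving compound 2 cannot be read. Nothing given here accounts for this result.

Going by these compounds, the place of 3,4-dichlorophenyl stays unknown. Also open, on these data alone, is how an amine or a carboxylic acid on the phenyl group, or a longer chain at this position, would read.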